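A few compounds are considered here, and "the series" means these few. Any claim that something is new, unique, unknown or untested is made for them only; others in the source may bear on it.

Compound 1 `CN[C@@H](CC(C)C)CN(C(=O)[C@@H]1C[C@H]1c1ccccc1)c1ccc(-c2ccccc2)cc1` — in a functional assay for agonist activity at G protein-coupled receptor 88 (Homo sapiens), read by HTRF and cAMP accumulation (on this read-out lower numbers stand for an effect already at smaller amounts and higher numbers for an effect only at larger amounts of compound), compound 1 gives 2 nM.
Compound 2 `CC[C@H](C)[C@H](N)CN(C(=O)[C@@H]1C[C@H]1c1ccc(F)cc1)c1ccc(-c2ccccc2)cc1` — in this assay compound 2 gives 600 nM.

Of the two measured compounds, compound 2 stands at the higher number, and its gap to compound 1 is far beyond the usual scatter; the two compounds differ in several places at once, so nothing single can be read from that gap.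

Compound 3 `CC[C@H](C)[C@H](N)CN(C(=O)[C@@H]1C[C@H]1c1nc(C)cs1)c1ccc(-c2ccccc2)cc1` has not yet been measured. It departs from compound 2 in one place: 4-methyl-1,3-thiazol-2-yl in place of 4-fluorophenyl on a saturated ring carbon. Among the measured compounds shown here, no measured pair shows what this exchange does on the shared core, so the direction of the step is open.

Compound 3 is expected to land near compound 2, with the step of a 1.3-fold higher number from compound 2 to compound 3 (0.12 log units; within the scatter) estimated as small, if anything toward a slightly higher number. For compound 3 in this assay the estimate is 800 nM, within a range from 200 nM to 3000 nM.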

Compound 3, half-maximal effective concentration: 730 nM
Compound 3: middle estimate off by 1.1-fold (0.04 log units), on the high side, and the stated range covers the measured number.
By their numbers in this assay, from the lowest: compound 1; then compounds 2 and 3 (each within the scatter of the next).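

In this assay, putting 4-methyl-1,3-thiazol-2-yl in place of 4-fluorophenyl on the saturated ring carbon gives a 1.2-fold higher number from compound 2 to compound 3 (0.09 log units; within the scatter) and so leaves the two compounds indistinguishable. Among the compounds shown here, this is the first pair that differs in one place only, and it shows that on this shared core, a six-membered aromatic ring of carbon only and a five-membered aromatic ring with 2 hetero atoms can stand at this position without a difference beyond the scatter. Nothing at hand says why the exchange makes so little difference.

Still open, going by these compounds, is whether the same exchange would behave alike on the core of compound 1. Also open, on these data alone, is what a thiazole ring without its methyl group, a pyridine ring or a carboxylic acid would do at this position.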